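This account rests on a few compounds, and the source may have more. Where it says the series, first, only, none or still open, it means among the compounds named here.

In a functional assay on COLO 205 cells (Homo sapiens) for inhibition, read by sulforhodamine B assay, with a stated time of 48 h, tested at 50 uM (on this read-out lower numbers stand for less inhibition of growth and higher numbers for more inhibition of growth at the one concentration tested), compound 1 `COc1ccc(/C=C/C(=O)/C=C/c2ccc(OCc3cn(CCCCCOc4cc(=O)oc5ccccc45)nn3)c(OC)c2)cc1OC` gives 43% and compound 2 `COc1cccc(/C=C/C(=O)/C=C/c2ccc(OCc3cn(CCCCCOc4cc(=O)oc5ccccc45)nn3)c(OC)c2)c1` gives 34%. For the measured compounds named here, these are the only two numbers so far, and they lie within the scatter of each other, so compound 2 stands level with compound 1 rather than clearly apart from it. Compound 3 `COc1cc(/C=C/C(=O)/C=C/c2cccs2)ccc1OCc1cn(CCCCCOc2cc(=O)oc3ccccc23)nn1` keeps the rest of compound 2 and alters one group: thiophen-2-yl in place of 3-methoxyphenyl on a double-bonded chain carbon bound to a double-bonded chain carbon. In words, this is thiophen-2-yl in place of 3-methoxyphenyl on a double-bonded chain carbon bound to a double-bonded chain carbon. Going by the values given here, only one measured step bears on this, and only in part. That step, a number 9 percentage points lower from compound 1 to compound 2 (within the scatter), is hydrogen in place of methoxy on an aromatic carbon of the ring that leaves in compound 3. Among the compounds with values here, no measured pair shows a whole ring being exchanged, so the data give no direction for this change. The expected outcome in this assay is therefore no shift beyond the scatter, and the estimated move is a number 1 percentage points lower from compound 2 to compound 3 (within the scatter). For compound 3 the estimated value is 33%, with an expected range from 18% to 48%.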

Compound 3, percent growth inhibition at one concentration: 30%
Compound 3: the middle estimate sits 3 percentage points above what was measured, and the stated range covers the measured number.
By their numbers in this assay, from the lowest: compounds 3, 2 and 1 (each within the scatter of the next, the first and the last beyond it).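

In this assay, a whole ring has now been exchanged at this position: putting thiophen-2-yl in place of 3-methoxyphenyl gives a number 4 percentage points lower from compound 2 to compound 3 (within the scatter) and so leaves the two compounds level, even though the entering ring is a smaller, five-membered ring that carries sulfur. For the compounds shown here, measured against the 3,4-dimethoxyphenyl ring, the same thiophen-2-yl gives a number 13 percentage points lower from compound 1 to compound 3 (beyond the scatter) as the first step in this set to clear the scatter, which shows that the group on this chain carbon can move the growth inhibition, though only modestly and only in this one comparison. No measurement is available that would explain either step.

From the compounds shown here alone, what a furan-2-yl or pyridin-3-yl ring would give on this same chain carbon stays open, as does the effect of a phenyl ring bearing a dimethylamino group or a carboxylic acid. All three numbers also come from one concentration, so they leave open how these compounds would compare across a range of concentrations, and whether the modest step seen here would hold at lower or higher doses.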